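The compounds below may be only part of what the source reports. "The series", "measured", "known", "first", "only" and "open" are said of these compounds alone.

Compound 1 `CCCCCCc1cc2cn(Cc3cn(-c4ccccc4F)nn3)c(=O)nc2o1` gives 69200 nM in an ADME assay on WI-38 cells (Homo sapiens) for antiproliferative activity, read by MTT assay, with a stated time of 72 h; a higher number here means a weaker inhibitor, a lower number a stronger inhibitor.
Compound 2 `O=c1nc2oc(CCCCl)cc2cn1Cc1cn(-c2ccccc2F)nn1` gives 76500 nM.
Compound 3 `O=c1nc2oc(CCCCl)cc2cn1Cc1cn(-c2ccc(F)cc2)nn1` gives < 10 nM, which is a limit of the assay and not a number.

Two measured steps connect these compounds. The step of a 1.1-fold higher number from compound 1 to compound 2 (0.04 log units; within the scatter) changes the chain on the shared core and stays within the scatter. The step of an at least 7600-fold lower number from compound 2 to compound 3 (3.88 log units; beyond the scatter) changes only where the fluorine sits on the phenyl ring attached to the triazole nitrogen, and it is large. Compound 3 thus sits at the limit (the limit of < 10 nM in this assay, at which 1 of the 3 values shown sits); its true value is only known to lie at or beyond it.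

Compound 4 `O=c1nc2oc(CCCCl)cc2cn1Cc1cn(Cc2ccccc2)nn1` is the next compound, with the change (benzyl in place of 4-fluorophenyl on an aromatic nitrogen). For the measured compounds named here, no measured step touches a benzyl group, so none bears directly on this change. Going by the values given here, the one large step, from a 2-fluorophenyl to a 4-fluorophenyl, shows that this position is sensitive to small changes, and the fluorine that marked compound 3 is removed here. The expectation for compound 4 in this assay is therefore a higher number than compound 3, with a wide range, as the step of an at least 50-fold higher number from compound 3 to compound 4 (1.69 log units; beyond the scatter) expresses. Compound 4 is estimated at 500 nM, between 10 nM and 50000 nM.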

Compound 4, half-maximal inhibitory concentration: 5200 nM
Compound 4: the middle estimate sits 10-fold (1.02 log units) below what was measured, within the range that was stated.
By their numbers in this assay, from the lowest: compound 4; then compounds 1 and 2 (each within the scatter of the next). At a limit, below all of these: compound 3.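

In this assay, for the compounds shown here, this aromatic nitrogen had so far carried only fluorophenyl groups, which left open whether a strong result depended on a fluorine-bearing ring attached directly to that nitrogen. Benzyl has the same number of heavy atoms as 4-fluorophenyl and carries no fluorine, and it gives an at least 520-fold higher number from compound 3 to compound 4 (2.71 log units; beyond the scatter), yet in place of 2-fluorophenyl it gives a 15-fold lower number from compound 2 to compound 4 (1.17 log units; beyond the scatter), so compound 4 falls clearly between the two fluorophenyl compounds and fluorine is not needed for a gain over compound 2. Compound 3 stands at a limit of the assay, so the full size of the step from it remains unknown: the limit of < 10 nM in this assay, at which 1 of the 4 values shown sits.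

The compounds shown leave open how a plain phenyl group without fluorine, or a longer chain ending in the same ring, would behave at this nitrogen, and so whether the fluorine or the extra carbon of benzyl accounts for any part of these steps. They also leave open whether the striking result with 4-fluorophenyl would hold with the chain of compound 1 on the shared core.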